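This account rests on a few compounds, and the source may have more. Where it says the series, first, only, none or still open, it means among the compounds named here.

Measured compounds:
Compound 1 `CC[C@@H]1C(=O)N(C)c2cnc(-n3ccc4cc(F)ccc43)nc2N1C1CCCC1` gives 21200 nM
Compound 2 `CCC1C(=O)N(C)c2cnc(Nc3ccc(S(N)(=O)=O)cc3)nc2N1c1ccn(C)n1` gives "not active" (no number reported)

Within the data shown here, in a functional assay on K562 cells (Homo sapiens) for antiproliferative activity, read by CCK-8 assay, with a stated time of 72 h (a lower number here means a stronger inhibitor of growth, a higher number a weaker inhibitor of growth), compound 1 is the only compound with a number; compound 2 returned no number at all. Compound 3 `CCNC(=O)c1ccc2c(ccn2-c2ncc3c(n2)N(C2CCCC2)[C@H](CC)C(=O)N3C)c1` has not been measured. Its difference from compound 1 is ethylcarbamoyl in place of fluoro on an aromatic carbon: the fluoro leaves and the ethylcarbamoyl enters on the ring that is part of a fused system of two rings. Among the measured compounds shown here, with no measured step to guide the size, a modest gain beyond the scatter is expected here, since compound 1 leaves ample room for improvement at 21200 nM. The expected step is a 3.5-fold lower number from compound 1 to compound 3 (0.55 log units; beyond the scatter). Compound 3 is estimated at 6000 nM, within 1200 nM to 25000 nM.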

Compound 3, concentration for 50% growth inhibition: 428 nM
Beside the measured number, compound 3's estimate is 14-fold (1.15 log units) above it; measured number outside the range, below it.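

In this assay, among these compounds, ethylcarbamoyl in place of fluoro on this aromatic carbon gives a 50-fold lower number from compound 1 to compound 3 (1.69 log units; beyond the scatter) and this large step is the first measured change at this position. The position therefore responds strongly to the group it carries, and the larger ethylcarbamoyl goes with the lower number. No measurement shown explains the size of this step.

Among the compounds shown here, with only this pair, the roles of the amide hydrogen and the ethyl chain remain open. A carboxylic acid, an amine or a longer chain at this carbon would test how much each part contributes.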